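The source may report more compounds than this note shows. Statements on the series, on what has been measured and on what is new or still open speak of the compounds shown alone.

Compound 1 `O=C(CCl)Nc1ccc(C(=O)/C=C/c2ccc(F)cc2)cc1` and compound 2 `O=C(CCl)Nc1ccc(C(=O)/C=C/c2ccccc2Cl)cc1` share a core and differ in one place: 2-chlorophenyl in place of 4-fluorophenyl on a double-bonded chain carbon bound to a double-bonded chain carbon. In a functional assay on MGC-803 cells (Homo sapiens) for cytotoxicity, read by MTT assay, with a stated time of 72 h (a higher number here means a weaker inhibitor, a lower number a stronger inhibitor), compound 1 gives 4680 nM, while compound 2 gives 2750 nM, so the step of a 1.7-fold lower number from compound 1 to compound 2 (0.23 log units; within the scatter) is small. Compound 3 `O=C(CSC(=S)N[C@H]1CCOC1=O)Nc1ccc(C(=O)/C=C/c2ccc(F)cc2)cc1` has a different core; how it differs from compound 1 is a group of 10 heavy atoms (5 carbon, 1 nitrogen, 2 oxygen, 2 sulfur; one five-membered non-aromatic ring with 1 hetero atom) in place of one chlorine atom, on a saturated chain carbon bound to a carbonyl carbon, and in this assay compound 3 gives 45700 nM, a step of a 9.8-fold higher number from compound 1 to compound 3 (0.99 log units; beyond the scatter). Compound 4 `O=C(CSC(=S)N[C@H]1CCOC1=O)Nc1ccc(C(=O)/C=C/c2ccccc2Cl)cc1` stands to compound 3 as compound 2 stands to compound 1, namely (2-chlorophenyl in place of 4-fluorophenyl on a double-bonded chain carbon bound to a double-bonded chain carbon), in the same place, so this is the same change made on the second core. Since the earlier step stayed within the scatter, the step from compound 3 to compound 4 is expected to be similar, about a 1.5-fold lower number from compound 3 to compound 4 (0.18 log units; within the scatter). On that basis, compound 4 is estimated at 30000 nM, plausibly between 12000 nM and 75000 nM.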

Compound 4, half-maximal inhibitory concentration: 12400 nM
Compound 4: middle estimate off by 2.4-fold (0.38 log units), on the high side, and the stated range covers the measured number.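

In this assay, 2-chlorophenyl in place of 4-fluorophenyl gives a 3.7-fold lower number from compound 3 to compound 4 (0.57 log units; beyond the scatter), and this step does not differ beyond the scatter from the same change on the other core: the same change on two cores in this assay, a 1.7-fold lower number (0.23 log units; within the scatter) from compound 1 to compound 2 and a 3.7-fold lower number (0.57 log units; beyond the scatter) from compound 3 to compound 4, 2.2-fold (0.34 log units) apart, within the scatter of two such steps. The group with the five-membered ring in place of chlorine, on a saturated chain carbon bound to a carbonyl carbon, gives a 4.5-fold higher number from compound 2 to compound 4 (0.65 log units; beyond the scatter), and the two steps for this change also agree: the same change on two cores in this assay, a 9.8-fold higher number (0.99 log units; beyond the scatter) from compound 1 to compound 3 and a 4.5-fold higher number (0.65 log units; beyond the scatter) from compound 2 to compound 4, 2.2-fold (0.34 log units) apart, within the scatter of two such steps. So both changes carry between these two cores, but two pairs cannot show that they would carry to any further core, nor what lies behind the steps.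

As far as these compounds go, it remains open whether a plain phenyl on the double-bonded chain carbon, or an amine in place of chlorine on the saturated chain carbon, would follow the same pattern.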